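Ortho-azolyl aryloxymethyl imidazolines at the alpha-1B receptor

The compounds below may be only part of what the source reports. "The series", "measured", "known", "first", "only" and "open" are said of these compounds alone.

Measured so far:
compound 1 `c1coc(-c2ccccc2OCC2=NCCN2)c1` — 10 nM
compound 2 `c1ccc(-c2ccoc2)c(OCC2=NCCN2)c1` — 5.01 nM
compound 3 `c1ccc(-c2cc[nH]n2)c(OCC2=NCCN2)c1` — 79.4 nM

In a functional assay for activation of Alpha-1B adrenergic receptor (Homo sapiens), read by calcium flux (on this read-out lower numbers stand for an effect already at smaller amounts and higher numbers for an effect only at larger amounts of compound), compound 3 holds the highest number of the three. Its nearest neighbour is compound 1, with a 7.9-fold higher number from compound 1 to compound 3 (0.90 log units; beyond the scatter) separating them; the furthest is compound 2, a 16-fold higher number from compound 2 to compound 3 (1.20 log units; beyond the scatter) away. The two furans sit together, a 2.0-fold lower number from compound 1 to compound 2 (0.30 log units; within the scatter) between them.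

Compound 4 `Cn1nccc1-c1ccccc1OCC1=NCCN1` is the next member: 1-methyl-1H-pyrazol-5-yl in place of 1H-pyrazol-3-yl on an aromatic carbon. For the measured compounds named here, no measured step has this exact change, so the only guide is the pair of steps into compound 3, in which the furans gave lower numbers than the pyrazole that carries a ring hydrogen. On that basis a step back toward the furan values is plausible, but it may equally fall within the scatter. The estimate for compound 4 in this assay is 50 nM, between 12 nM and 200 nM, which means an expected 1.6-fold lower number from compound 3 to compound 4 (0.20 log units; within the scatter).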

Compound 4, half-maximal effective concentration: < 100000 nM
Compound 4 ended at the assay's limit; the forecaster's own chance of this, stated with the estimate: 5%; the middle value does not contradict the limit.
By their numbers in this assay, from the lowest: compounds 2 and 1 (each within the scatter of the next); then compound 3.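

In this assay compound 4 gives < 100000 nM, which is a limit of the assay and not a number. For the compounds shown here, no step from compound 1, compound 2 or compound 3 to compound 4 can be read. The compounds shown leave open where compound 4 stands relative to these three.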